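Neopentyl in Place of Amino on the Shared Core

The compounds below may be only part of what the source reports. "The series", "measured", "known", "first", "only" and "open" are said of these compounds alone.

Measured compounds:
- compound 1, `Nc1ccc2nc(N)sc2c1`: > 10 mg/kg (a limit, not a number)
- compound 2, `CC(C)c1ccc2nc(N)sc2c1`: > 10 mg/kg (a limit, not a number)

In a functional assay on the whole organism with Rattus norvegicus as the target (a lower number here means that less compound is needed, a higher number that more compound is needed for the effect), compound 1 reaches only a limit, > 10 mg/kg. Compound 2 likewise reaches only a limit, > 10 mg/kg. The step that the two limits leave unreadable from compound 1 to compound 2 is therefore not readable, since both values sit at the limit of > 10 mg/kg in this assay, at which 2 of the 2 values shown sit. Compound 3, `CC(C)(C)Cc1ccc2nc(N)sc2c1`, differs from compound 1 by neopentyl in place of amino on an aromatic carbon. Among the measured compounds shown here, the single measured step that bears on this change, the one carrying isopropyl in place of amino, has no readable size, so it gives no direction for the neopentyl change and no step beyond the scatter can be expected or excluded. Compound 3 is therefore expected to show a step that the limit leaves unreadable from compound 1 to compound 3 whose size remains uncertain, most probably ending again at a limit. The estimate for compound 3 in this assay is 20 mg/kg, within 6 mg/kg to 70 mg/kg.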

Compound 3, dose for half-maximal effect: > 10 mg/kg
Compound 3: only a limit was reported (the forecaster's own chance of this, stated with the estimate: 75%); the middle value lies beyond the limit too.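

Among the compounds shown here, compound 3, like compound 1 and compound 2, reaches only a limit in this assay, so no step among the three can be read: the limit of > 10 mg/kg in this assay, at which 3 of the 3 values shown sit. The compounds shown leave open what dose any of the three needs, and whether amino, isopropyl or neopentyl on the shared core changes it.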